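The source may hold more compounds than are shown below. What is called first, only, known or untested is meant among the compounds shown, and "the series" means these compounds.

Measured so far:
compound 1 `Cc1cccc(S(=O)(=O)NCc2ccc(CNC(=O)c3ccc(CNc4ncccn4)cc3)cc2)c1` — 100 nM
compound 2 `O=C(NCc1ccc(CNS(=O)(=O)c2ccccc2Cl)cc1)c1ccc(CNc2ncccn2)cc1` — 1000 nM

For the measured compounds named here, in an assay on MDA-MB-231 cells for binding affinity to C-X-C chemokine receptor type 4 (Homo sapiens), read by microscopy, with stated times of 10 min and 30 min (on this read-out lower numbers stand for an effect already at smaller amounts and higher numbers for an effect only at larger amounts of compound), compound 2 gives the highest of the two numbers; the only measured step is a 10-fold higher number from compound 1 to compound 2 (1.00 log units; beyond the scatter), and it lies beyond the scatter. Going by the values given here, that step, 3-methylphenyl to 2-chlorophenyl on the sulfonyl sulfur, swaps both the substituent and its ring position at once, so it does not isolate the chloro group; it shows only that substitution on this ring moves the read-out by that amount.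

Compound 3 `O=C(NCc1ccc(CNS(=O)(=O)c2ccccc2)cc1)c1ccc(CNc2ncccn2)cc1` differs from compound 2 by hydrogen in place of chloro on an aromatic carbon. Among the compounds with values here, no measured pair isolates this change. Given that the substituted rings in compound 1 and compound 2 bracket a wide span, the unsubstituted phenyl is expected to fall between them, nearer compound 2, with a modest drop in number, a 2.5-fold lower number from compound 2 to compound 3 (0.40 log units; beyond the scatter). Compound 3 is estimated at 400 nM, range 150 nM to 1500 nM.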

Compound 3, effective concentration (reported as EC, without a stated level of effect): 1 nM
The estimate for compound 3 lay 400-fold (2.60 log units) above the measured number; the whole stated range lies above it.
By their numbers in this assay, from the lowest: compound 3; then compound 1; then compound 2.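

In this assay the bare phenyl ring of compound 3 gives the lowest number of the three, and hydrogen in place of chloro on the aromatic carbon gives a 1000-fold lower number from compound 2 to compound 3 (3.00 log units; beyond the scatter) in this series. Hydrogen in place of methyl gives a 100-fold lower number from compound 1 to compound 3 (2.00 log units; beyond the scatter) as well, so the unsubstituted ring lies outside the span of the two substituted rings, and both substituents go with higher numbers, something the earlier pair could not show. No measurement here accounts for the size of these steps.

Still open, on these data alone, is whether the numbers follow the substituent or its place on the ring, as the 3-methylphenyl and 2-chlorophenyl rings differ in both. Also open, as far as these compounds go, is whether any group on this ring, such as fluoro, methoxy or an amine, keeps the low number of compound 3.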